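This account rests on a few compounds, and the source may have more. Where it says the series, first, only, none or still open, it means among the compounds named here.

Measured so far:
compound 1 `CCOC(=O)C1=CC(c2ccc(Br)cc2)C2=C(CC(C)(C)CC2=O)N1` — "not active" (no number reported)
compound 2 `CC1(C)CC(=O)C2=C(C1)NC(c1ccccc1)=CC2c1ccc(Cl)cc1` — 7.16%
compound 3 `CC1(C)CC(=O)C2=C(C1)NC(c1ccccc1)=CC2c1ccc([N+](=O)[O-])cc1` — "not active" (no number reported)

In an assay on isolated protein for inhibition of glucose-6-phosphatase catalytic subunit 1 (Homo sapiens), read by inositol phosphate accumulation, with a stated time of 30 min, tested at 100 uM (a higher number here means more inhibition at the concentration tested (going by the name of the read-out), a lower number less inhibition), compound 2 gives 7.16%, the only figure reported in this set; for compound 1 and compound 3 no number is reported, only that they are not active. Compound 2 thus stands alone as the single quantified entry, and its figure is small. Compound 4 `CCOC(=O)C1=CC(c2ccc(Cl)cc2)C2=C(CC(C)(C)CC2=O)N1` is not yet measured. It differs from compound 2 by ethoxycarbonyl in place of phenyl on a double-bonded ring carbon. Compound 1 carries the same ethoxycarbonyl group and is reported as not active, so no gain is expected from this change. The step of a number 2.2 percentage points lower from compound 2 to compound 4 (within the scatter) is estimated to stay within the scatter, with a fair chance that only "not active" is reported. For compound 4 an inhibition of 5% is expected, within -8% to 18%.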

Compound 4, a percentage reported as inhibition, at one concentration (the size of the read-out at that concentration, not a potency): 11.3%
Compound 4: middle estimate off by 6.3 percentage points, on the low side; the measured number falls inside the stated range.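

In this assay the position on the double-bonded ring carbon accepts a ringless ethoxycarbonyl in place of phenyl, with a number 4.1 percentage points higher from compound 2 to compound 4 (within the scatter), so the aromatic ring here is not needed to keep a measurable figure. Compound 1, which carries the same ethoxycarbonyl with bromine in place of chlorine, gives "not active" (no number reported) and compound 4 gives a number, so the outcome with this group also varies with the halogen-bearing aryl group. No measured evidence explains the step.

Still open, going by these compounds, is whether a carboxylic acid or an amine at this position would move inhibition beyond the scatter. A longer chain in the ester is equally unresolved.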